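The source may hold more compounds than are shown below. What is called first, only, known or untested is meant among the compounds shown, and "the series" means these compounds.

Measured in an ADME assay on BJ cells (Homo sapiens), read by MTT assay, with a stated time of 72 h; on this read-out lower numbers stand for stronger inhibition and higher numbers for weaker inhibition:
- compound 1 `CSc1ncnc2c1c(-c1ccoc1)cn2[C@@H]1O[C@H](CO)[C@@H](O)[C@H]1O`: 98800 nM
- compound 2 `CN(C)c1ncnc2c1c(-c1ccoc1)cn2[C@@H]1O[C@H](CO)[C@@H](O)[C@H]1O`: 99200 nM

These two numbers are the only ones available, and they lie within the scatter of each other, so compound 2 sits level with compound 1. Compound 3 `Cc1ncnc2c1c(-c1ccoc1)cn2[C@@H]1O[C@H](CO)[C@@H](O)[C@H]1O` carries methyl in place of dimethylamino on an aromatic carbon. Among the compounds with values here, the one measured step bearing on this, a 1.0-fold higher number from compound 1 to compound 2 (0.00 log units; within the scatter), is within the scatter. It involved no methyl, so it is only a weak guide. No step beyond the scatter is therefore expected, though the uncertainty is wide. The expected change is a 1.4-fold lower number from compound 2 to compound 3 (0.15 log units; within the scatter). Compound 3 is estimated at 70000 nM, with an expected range of 10000 nM to 120000 nM.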

Compound 3, half-maximal inhibitory concentration: 89200 nM
For compound 3 the middle estimate is 1.3-fold (0.11 log units) below the measured one, and the stated range covers the measured number.
By their numbers in this assay, from the lowest: compounds 3, 1 and 2 (each within the scatter of the next).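

In this assay methyl in place of dimethylamino gives a 1.1-fold lower number from compound 2 to compound 3 (0.05 log units; within the scatter) and methyl in place of methylsulfanyl gives a 1.1-fold lower number from compound 1 to compound 3 (0.04 log units; within the scatter) so the number stays level even with a smaller group that has no hydrogen-bond acceptor. At this place on the aromatic carbon, all three groups shown therefore give matching numbers. Nothing measured here offers a reason for this.

On these data alone, whether a primary amine, a carboxylic acid or a longer alkyl chain at this place would also leave the number level remains open.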